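Replacing the isopropyl group of compound 2

This account rests on a few compounds, and the source may have more. Where it says the series, first, only, none or still open, it means among the compounds named here.

In a functional assay on MDA-MB-231 cells (Homo sapiens) for antiproliferative activity, read by MTT assay, with a stated time of 72 h (a higher number here means a weaker inhibitor, a lower number a stronger inhibitor), compound 1 `CC(C)(C)c1ccc(NC(=O)CCc2cccc3c2B(O)OC3)cc1` gives 33000 nM, compound 2 `CC(C)c1cccc(NC(=O)CCc2cccc3c2B(O)OC3)c1` gives 1600 nM, and compound 3 `O=C(CCc1cccc2c1B(O)OC2)Nc1cccc2ccccc12` gives 150 nM. Compound 2 therefore sits in the middle, with both gaps beyond the scatter. Compound 4 `COc1cc(OC)cc(-c2cccc(NC(=O)CCc3cccc4c3B(O)OC4)c2)c1` has 3,5-dimethoxyphenyl in place of isopropyl on an aromatic carbon. Among the measured compounds shown here, no measured pair isolates this change, so the expectation is loose. Compound 3, at 150 nM, shows that a larger aromatic group can accompany a low number, while compound 1, at 33000 nM, warns against any simple size trend. A modest fall in this assay is expected, with an estimated 2.3-fold lower number from compound 2 to compound 4 (0.36 log units; beyond the scatter). For compound 4 the estimate is 700 nM, with an expected range of 90 nM to 5000 nM.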

Compound 4, half-maximal inhibitory concentration: 40 nM
Beside the measured number, compound 4's estimate is 18-fold (1.24 log units) above it, outside the stated range (below it).
By their numbers in this assay, from the lowest: compound 4; then compound 3; then compound 2; then compound 1.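

In this assay, among the compounds shown here, the aromatic carbon meta to a large group accepts a much larger substituent than isopropyl: 3,5-dimethoxyphenyl brings a 40-fold lower number from compound 2 to compound 4 (1.60 log units; beyond the scatter), the first step that isolates a single change. The new aromatic ring and the two hydrogen-bond acceptors enter together, so this step cannot assign the gain to either one. Nothing available explains the gain. The compounds shown leave open whether an unsubstituted phenyl would match compound 4. From the compounds shown here alone, it is also open whether one methoxy group, or an amine in place of each methoxy group, would keep the gain.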